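From methyl to isopropyl on a sulfur

The source may report more compounds than this note shows. Statements on the series, on what has been measured and on what is new or still open speak of the compounds shown alone.

In a functional assay on HeLa cells (Homo sapiens) for antiproliferative activity, read by resazurin assay (a lower number here means a stronger inhibitor, a higher number a weaker inhibitor), compound 2 (`CSC(=S)SCC(=O)c1ccc(Cl)c(Cl)c1`) gives 6310 nM. That value lies within the scatter of compound 1 (`CCSC(=S)SCC(=O)c1ccccc1`) at 5010 nM, while compound 3 (`CCOC(=O)Nc1cccc(C(=O)CSC(=S)SCC)c1`) gives a lower 2000 nM, beyond the scatter. The next structure, compound 4 (`CC(C)SC(=S)SCC(=O)c1ccc(Cl)c(Cl)c1`), has isopropyl in place of methyl on a sulfur.

Among the measured compounds shown here, no measured step changes the group on that sulfur alone. For the measured compounds named here, the only step available, a 2.5-fold lower number from compound 1 to compound 3 (0.40 log units; beyond the scatter), was modest and came from a change on an aromatic carbon, so it bears on this change only weakly. Compound 1 at 5010 nM and compound 2 at 6310 nM differ at that sulfur and elsewhere, yet their values stay within the scatter. Nothing therefore points to a clear shift in either direction in this assay, and the expected step, a 1.3-fold lower number from compound 2 to compound 4 (0.10 log units; within the scatter), is none beyond the scatter. For compound 4 the estimated value is 5000 nM, with an expected range from 2000 nM to 12500 nM.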

Compound 4, half-maximal inhibitory concentration: 25100 nM
Estimate against measurement, compound 4: 5.0-fold (0.70 log units) below, outside the stated range (above it).
By their numbers in this assay, from the lowest: compound 3; then compounds 1 and 2 (each within the scatter of the next); then compound 4.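

In this assay, among the compounds shown here, the step from methylsulfanyl to isopropylsulfanyl gives a 4.0-fold higher number from compound 2 to compound 4 (0.60 log units; beyond the scatter), and it is the first measured step in which the group on this sulfur changes alone. For the compounds shown here, it shows that this position, on a sulfur whose other neighbour is the thiocarbonyl carbon, is sensitive to the group it carries, which the earlier compounds could not show because none of them formed a single-change pair at this sulfur. No measured evidence is available to explain the step.

From the compounds shown here alone, whether an ethyl group or a longer straight chain such as n-butyl on this sulfur of the core of compound 2 would track methyl or isopropyl remains open. Going by these compounds, it is also open whether an amine or a carboxylic acid at the end of such a chain would be tolerated at this position.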